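Aryl in place of bromo on the acid ceramidase inhibitor core

This account rests on a few compounds, and the source may have more. Where it says the series, first, only, none or still open, it means among the compounds named here.

Three measured compounds set the frame. Compound 1 `O=C(NCCCCc1ccccc1)n1c(=O)oc2ccc(Br)cc21` gives 22 nM in an assay on HEK293 cells for inhibition of acid ceramidase (Homo sapiens), with a stated time of 10 min (on this read-out higher numbers stand for weaker inhibition and lower numbers for stronger inhibition), the lowest of the three numbers. Compound 2 `COc1ccc(-c2ccc3c(c2)oc(=O)n3C(=O)NCCCCc2ccccc2)cc1` gives 67 nM in this assay, and compound 3 `O=C(NCCSCc1ccccc1)n1c(=O)oc2ccccc21` gives 65 nM. Both of these stand beyond the scatter from compound 1, and compound 2 and compound 3 lie within the scatter of each other. Among the measured compounds shown here, none of the three pairs differs in a single place, so no single step can be drawn from them; compound 2 carries an aryl group on the shared core where compound 1 carries bromo, but at a different carbon, and compound 3 differs in both the chain and the core.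

The step to be followed is from compound 1 to compound 4 `O=C(NCCCCc1ccccc1)n1c(=O)oc2ccc(-c3ccc(F)cc3)cc21`: 4-fluorophenyl in place of bromo on an aromatic carbon. For the measured compounds named here, with no measured single-point step in hand, the expectation rests on the spread of the three numbers. Compound 4 is estimated at 40 nM in this assay, with a range of 15 nM to 110 nM. This means an expected step of a 1.8-fold higher number from compound 1 to compound 4 (0.26 log units; within the scatter), a modest move toward weaker inhibition that may not clear the scatter, since compound 2 with an aryl group on the core still gives 67 nM.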

Compound 4, half-maximal inhibitory concentration: 56 nM
For compound 4 the middle estimate is 1.4-fold (0.15 log units) below the measured one, within the range that was stated.
By their numbers in this assay, from the lowest: compound 1; then compounds 4, 3 and 2 (each within the scatter of the next).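

At the aromatic carbon that carries bromo in compound 1, the series now has its first single-place step: in this assay, 4-fluorophenyl in place of bromo gives a 2.5-fold higher number from compound 1 to compound 4 (0.41 log units; beyond the scatter) and so a modest weakening of inhibition that lies beyond the scatter. The step is large in atom count, with 7 heavy atoms and a six-membered aromatic ring of carbon only entering where 1 heavy atom leaves, yet compound 4 still gives 56 nM in this assay, so this position carries the added ring with only a modest loss. Neither group has a hydrogen-bond donor or acceptor, and no measurement in hand accounts for the size or direction of this step.

With one aryl group at this carbon, the compounds shown do not separate the contribution of the ring from that of its fluorine, a question that plain phenyl would address directly. Also open, from the compounds shown here alone, is how a small group such as chloro or methyl, or a ring bearing an amine or a carboxylic acid, would compare with bromo at this carbon on the same four-carbon-chain phenyl side of the molecule.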